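Thiophen-2-yl for cyclopropyl on the larger core

The source may report more compounds than this note shows. Statements on the series, on what has been measured and on what is new or still open speak of the compounds shown alone.

Three measured compounds share a core in which a saturated chain carbon bound to an aromatic carbon and a double-bonded nitrogen carries one variable group. Compound 1 `c1ccc(C(/N=C2\CCCCCN2)C2CC2)cc1` carries a cyclopropyl group there, and in a functional assay on the whole organism (plasma, strain Sprague-Dawley) with Rattus norvegicus as the target, with a stated time of 2 h, at a dose of 50 mg/kg by the oral route (a lower number here means a weaker effect, a higher number a stronger effect of the compound at the dose given), compound 1 gives 41%. Compound 2 `c1ccc(C(/N=C2\CCCCCCN2)C2CC2)cc1` keeps the cyclopropyl group on a core one carbon larger, and in this assay compound 2 gives 46%. Compound 3 `c1ccc(C(/N=C2\CCCCCN2)c2cccs2)cc1` carries a thiophen-2-yl group on the core of compound 1, and in this assay compound 3 gives 46%. Compound 2 stands level with compound 3 at the digits printed, and its gap to compound 1 lies within the usual scatter of repeated measurements, so no order among the three can be read from these numbers.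

Compound 4 `c1ccc(C(/N=C2\CCCCCCN2)c2cccs2)cc1` has not yet been measured. It differs from compound 2 in one place: thiophen-2-yl in place of cyclopropyl on a saturated chain carbon bound to an aromatic carbon and a double-bonded nitrogen. The same exchange has been measured once, on the smaller core, as a number 5 percentage points higher from compound 1 to compound 3 (within the scatter). Because a number 5 percentage points higher from compound 1 to compound 3 (within the scatter) lay within the scatter, the step expected in this assay is a number 3 percentage points higher from compound 2 to compound 4 (within the scatter), with no change beyond the scatter. Compound 4 is therefore estimated at 49%, within a range from 35% to 62%.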

Compound 4, a percentage reported as inhibition, in the whole organism at one dose (the size of the read-out at that dose, not a potency): 37%
The estimate for compound 4 lay 12 percentage points above the measured number; low and high end bracket the measured number.
By their numbers in this assay, from the lowest: compounds 4, 1, 2 and 3 (each within the scatter of the next).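

On the larger core, thiophen-2-yl in place of cyclopropyl gives in this assay a number 9 percentage points lower from compound 2 to compound 4 (within the scatter), so the same exchange can now be read on two cores. The two steps have opposite signs, which might suggest that the outcome of the exchange depends on the core, but the numbers do not support this: the same change on two cores in this assay, a number 5 percentage points higher (within the scatter) from compound 1 to compound 3 and a number 9 percentage points lower (within the scatter) from compound 2 to compound 4, 14 percentage points apart, within the scatter of two such steps. At this position, on a saturated chain carbon bound to an aromatic carbon and a double-bonded nitrogen, replacing a three-membered non-aromatic ring of carbon only with a five-membered aromatic ring with 1 hetero atom has therefore produced no change beyond the scatter on either core.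

The compounds shown leave open whether a different kind of group on this carbon, such as an amine or a carboxylic acid, would move the read-out in this assay beyond the scatter. As far as these compounds go, the read-out also gives the size of the effect at one dose only, so how these compounds compare in potency remains open.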